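Lengthening the vinyl group of compound 2

The compounds below may be only part of what the source reports. "The series", "measured", "known", "first", "only" and "open" are said of these compounds alone.

Going by the values given here, in a functional assay on A549 cells (Homo sapiens) for inhibition, read by MTT assay, with a stated time of 72 h (a higher number here means a weaker inhibitor, a lower number a stronger inhibitor), compound 2 `C=CC(=O)Nc1cc(Nc2nc3c(c(-c4cn(C)c5ccccc45)n2)CSCC3)c(OC)cc1N(C)CCN(C)C` holds the lower of the two numbers so far, at 506 nM against compound 1 `C=CC(=O)Nc1cc(Nc2nc3c(c(-c4cn(C)c5ccc(F)cc45)n2)CSCC3)c(OC)cc1N(C)CCN(C)C` at 4550 nM in the same read-out. Among the compounds with values here, the only measured step, a 9.0-fold lower number from compound 1 to compound 2 (0.95 log units; beyond the scatter) on swapping to hydrogen in place of fluoro on an aromatic carbon, is modest but beyond the scatter.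

Compound 3 `COc1cc(N(C)CCN(C)C)c(NC(=O)/C=C\C(C)C)cc1Nc1nc2c(c(-c3cn(C)c4ccccc34)n1)CSCC2` carries a change elsewhere: 3-methylbut-1-en-1-yl in place of vinyl on a carbonyl carbon with 3-methylbut-1-en-1-yl in place of vinyl on a carbonyl carbon. Within the data shown here, no measured step touches this place, so the data offer no direct guide. The step of a 9.0-fold lower number from compound 1 to compound 2 (0.95 log units; beyond the scatter) serves only as a gauge of how far one change can move this assay in this pair. Compound 2 at 506 nM is also the lowest number seen, so a move of broadly similar or smaller size toward a higher number is expected, with low confidence. The estimated move is a 3.6-fold higher number from compound 2 to compound 3 (0.55 log units; beyond the scatter) in this assay as a working figure. The expected value for compound 3 is 1800 nM with an estimated range from 500 nM to 6500 nM for now.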

Compound 3, half-maximal inhibitory concentration: 788 nM
Compound 3: middle estimate off by 2.3-fold (0.36 log units), on the high side; the measured number falls inside the stated range.
By their numbers in this assay, from the lowest: compounds 2 and 3 (each within the scatter of the next); then compound 1.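

In this assay, going by these compounds alone, the first reading at this place, a carbonyl carbon whose other neighbour is an amide-type nitrogen, shows a 1.6-fold higher number from compound 2 to compound 3 (0.19 log units; within the scatter) with 3-methylbut-1-en-1-yl in place of vinyl. The pair therefore cannot be separated in this assay, so this larger chain, which keeps its double bond outside aromatic rings, leaves the number within the scatter, whereas the aromatic change, a 9.0-fold lower number from compound 1 to compound 2 (0.95 log units; beyond the scatter), lies beyond it. Nothing at hand accounts for either outcome, and no measurement bears on how the new group acts at this place.

Still open, on these data alone, is how far this place stays this flat: a longer saturated chain, or a dimethylaminomethyl group on the vinyl end, could remain within the scatter of compound 2 or could shift the number as far as the aromatic change did. Also open, as far as these compounds go, is whether fluoro on the aromatic carbon has the same effect when paired with 3-methylbut-1-en-1-yl on the carbonyl carbon, as the fluoro step is known only with vinyl at this place.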